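Replacing a trifluoromethoxyphenyl group on the pyrazolone nitrogen

A few compounds are considered here, and "the series" means these few. Any claim that something is new, unique, unknown or untested is made for them only; others in the source may bear on it.

The study reports two compounds in a functional assay on A549 cells (Homo sapiens) for cytotoxicity, read by MTT assay, with a stated time of 72 h; a higher number here means a weaker inhibitor, a lower number a stronger inhibitor. Compound 1 `Cc1cc(=O)n(-c2ccc(Br)cc2F)nc1C(=O)Nc1ccc(Oc2ncnc3[nH]ccc23)cc1` gives 3770 nM in this assay. Compound 2 `Cc1cc(=O)n(-c2ccccc2OC(F)(F)F)nc1C(=O)Nc1ccc(Oc2ncnc3[nH]ccc23)c(F)c1` gives 16200 nM, the higher of the two numbers; its nearest neighbour is compound 1, whose number is lower by more than the usual scatter, so compound 2 stands as the weaker of the two measured inhibitors.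

The step under consideration leads from compound 2 to compound 3 `Cc1cc(=O)n(-c2ccc(Br)cc2F)nc1C(=O)Nc1ccc(Oc2ncnc3[nH]ccc23)c(F)c1`, which has not yet been measured. The change is 4-bromo-2-fluorophenyl in place of 2-(trifluoromethoxy)phenyl on an aromatic nitrogen. For the measured compounds named here, no step between two measured compounds isolates this exchange, so its effect can only be inferred. Compound 1, which also bears a 4-bromo-2-fluorophenyl group, gives the lower of the two numbers, and for that reason a decrease in the number, that is a stronger inhibitor, is expected from compound 2 to compound 3, of about a 3.6-fold lower number from compound 2 to compound 3 (0.56 log units; beyond the scatter). Compound 3 is therefore estimated at 4500 nM in this assay, within a range from 1500 nM to 13000 nM.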

Compound 3, half-maximal inhibitory concentration: 6120 nM
Compound 3: middle estimate off by 1.4-fold (0.13 log units), on the low side; low and high end bracket the measured number.
By their numbers in this assay, from the lowest: compounds 1 and 3 (each within the scatter of the next); then compound 2.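

In this assay, the exchange on the aromatic nitrogen can now be read directly: 4-bromo-2-fluorophenyl in place of 2-(trifluoromethoxy)phenyl gives a 2.6-fold lower number from compound 2 to compound 3 (0.42 log units; beyond the scatter), a modest step beyond the scatter, so the reading responds to the group held at this place. For the compounds shown here, the second new comparison concerns a different place, where fluoro in place of hydrogen on an aromatic carbon gives a 1.6-fold higher number from compound 1 to compound 3 (0.21 log units; within the scatter), which lies within the scatter, so of the two single changes only the one on the nitrogen shows a readable effect in these compounds. No measurement offered here accounts for the step on the nitrogen.

The two groups differ in several features at once, so the compounds shown cannot separate the contribution of the bromo, the fluoro and the trifluoromethoxy substituents. From the compounds shown here alone, whether a plain phenyl group, a 4-chlorophenyl group or a 4-bromophenyl group on the same nitrogen would give a lower or higher number remains open.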